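Swapping the aryl group on a dihydropyran core

The source may hold more compounds than are shown below. What is called first, only, known or untested is meant among the compounds shown, and "the series" means these compounds.

Compound 1 `N#CC1=C(N)OC(c2c[nH]c3ccccc23)=C(C#N)C1c1ccc2ccccc2c1`, "not active" (no number reported)
Compound 2 `COc1ccc(C2C(C#N)=C(N)OC(c3c[nH]c4ccccc34)=C2C#N)cc1OC`, 19.1%

Of the compounds shown here, two sharing the same core have been tested in a functional assay, tested at 100 ug/mL; a higher number here means a stronger effect of the compound at the concentration tested, a lower number a weaker effect. Compound 1 was reported as "not active" (no number reported), without a number. For the measured compounds named here, compound 2 is therefore the only compound with a numerical result: in this assay compound 2 gives 19.1%, and no comparison between measured compounds can be drawn from a single number. Compound 3 `Cc1ccc(C2C(C#N)=C(N)OC(c3c[nH]c4ccccc34)=C2C#N)cc1` has not yet been measured. It differs from compound 2 as follows: 4-methylphenyl in place of 3,4-dimethoxyphenyl on a saturated ring carbon. Going by the values given here, with no measured pair to set the size of such a change, the expected step is a modest decrease, close to the scatter, since compound 1, which carries a different aryl group at the same place, gave no activity. For compound 3 the expected step is a number 7.1 percentage points lower from compound 2 to compound 3 (within the scatter). Compound 3 is estimated at 12%, with a range from 0% to 28%.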

Compound 3, a percentage reported as activity, at one concentration (the size of the read-out at that concentration, not a potency): 5.5%
Beside the measured number, compound 3's estimate is 6.5 percentage points above it; the range from low to high includes it.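

In this assay, this position on a saturated ring carbon now has its first readable step, a number 13.6 percentage points lower from compound 2 to compound 3 (beyond the scatter), which shows that the read-out responds to the choice of aryl group here. The change from 3,4-dimethoxyphenyl to 4-methylphenyl removes both methoxy groups and introduces a methyl group in one move, and the pair cannot separate these contributions. Nothing available bears on what lies behind this step.

The steps involving compound 1 cannot be read, as it has no number, and the aryl group it carries therefore remains unplaced relative to the other two compounds. The compounds shown leave open whether a single methoxy group, as in 4-methoxyphenyl, would give a read-out closer to that of compound 2, and how a 4-aminophenyl group would behave at this position.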